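The source may hold more compounds than are shown below. What is called first, only, known or untested is meant among the compounds shown, and "the series" means these compounds.

Compound 1, `COc1ccc(-c2ccc3oc(NC4CCCCC4)nc3c2)cc1C`: 228 nM
Compound 2, `Cn1ccc2cc(-c3ccc4oc(Cc5ccccc5)nc4c3)ccc21`: 488 nM

In an assay on HEK293 cells for inhibition of Fatty-acid amide hydrolase 1 (Homo sapiens), read by fluorescence (on this read-out lower numbers stand for stronger inhibition and higher numbers for weaker inhibition), compound 2 gives 488 nM, the highest of the two numbers shown, while compound 1 sits at 228 nM, a gap beyond the usual scatter. Compound 3, `Cn1ccc2cc(-c3ccc4oc(N5CCCC5)nc4c3)ccc21`, keeps the core of compound 2 and makes one change: pyrrolidin-1-yl in place of benzyl on an aromatic carbon. Going by the values given here, no measured pair shows this exact step, so its size is open; compound 1, with its value of 228 nM, is the only nearby point of comparison. Compound 3 is therefore expected to land near compound 2 or somewhat lower, a step of a 1.5-fold lower number from compound 2 to compound 3 (0.18 log units; within the scatter) within or just beyond the scatter. The estimate for compound 3 is 320 nM, with a range from 110 nM to 950 nM.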

Compound 3, half-maximal inhibitory concentration: 674 nM
For compound 3 the middle estimate is 2.1-fold (0.32 log units) below the measured one; the measured number falls inside the stated range.
By their numbers in this assay, from the lowest: compound 1; then compounds 2 and 3 (each within the scatter of the next).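

In this assay, the swap gives a 1.4-fold higher number from compound 2 to compound 3 (0.14 log units; within the scatter), so at this position pyrrolidin-1-yl and benzyl cannot be told apart. In this one pair, a six-membered aromatic ring of carbon gives way to a five-membered non-aromatic ring holding a nitrogen with no change beyond the scatter. No measurement shown offers an explanation for this. Still open, on these data alone, is how a methyl group or an open-chain amine such as diethylamino would read at this position. Compound 1 differs from compound 2 in more than one place, so its lower number cannot be tied to any single group.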